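This account rests on a few compounds, and the source may have more. Where it says the series, first, only, none or still open, it means among the compounds named here.

Measured in a physicochemical assay for solubility, measured as kinetic solubility, at pH 7.4; on this read-out lower numbers stand for lower solubility and higher numbers for higher solubility:
compound 1, `COc1cc(N2CCN(Cc3ccccn3)CC2)ccc1Nc1nc(NC2CCCCC2)c2nc[nH]c2n1`, gives 38000 nM.
compound 2, `COc1cc(N2CCC(C(=O)N3CCOCC3)CC2)ccc1Nc1nc(NC2CCCCC2)c2nc[nH]c2n1`, gives 19000 nM.

Compound 2 holds the lower of the two numbers; compound 1 sits close above it, within the scatter, so no order between the two is claimed. The unmeasured compound 3, `COc1cc(N2CCC(C(=O)N3CC(O)C3)CC2)ccc1Nc1nc(NC2CCCCC2)c2nc[nH]c2n1`, differs from compound 2 by 3-hydroxyazetidin-1-yl in place of morpholin-4-yl on a carbonyl carbon. Within the data shown here, no measured pair shows this change, so its size is unknown from the data. The expected step of a 1.3-fold higher number from compound 2 to compound 3 (0.12 log units; within the scatter) is one that stays within the scatter, with no settled direction. For compound 3 the estimate in this assay is 25000 nM, with a range from 10000 nM to 60000 nM.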

Compound 3, solubility: 19000 nM
For compound 3 the middle estimate is 1.3-fold (0.12 log units) above the measured one; measured number inside the range.
By their numbers in this assay, from the lowest: compounds 2, 3 and 1 (each within the scatter of the next).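

In this assay, the first read at this position gives no change at the digits printed from compound 2 to compound 3 (within the scatter) for 3-hydroxyazetidin-1-yl in place of morpholin-4-yl on a carbonyl carbon. At this carbonyl, then, a one four-membered ring carrying 1 hydrogen-bond donor and a six-membered ring with 0 hydrogen-bond donors cannot be told apart on this read-out. No measured evidence accounts for this result.

Still open, on these data alone, is how a piperazin-1-yl or dimethylamino group would read on the same carbonyl carbon. As far as these compounds go, a carboxylic acid in place of the whole amide is equally open.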